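The source may hold more compounds than are shown below. What is called first, only, known or untested is meant among the compounds shown, and "the series" means these compounds.

Measured so far: compound 1 `O=C(O)c1ccc2nc(CN3CCC[C@H](O[C@H](CO)c4cc(Cl)cc(Cl)c4)[C@@H]3c3ccccc3)[nH]c2c1` with 43000 nM in an assay on isolated protein for activation of cGMP-dependent protein kinase 1 (Homo sapiens), read by ADP-Glo, with stated times of 30 min and 2 h (a lower number here means that less compound is needed, a higher number that more compound is needed for the effect), and compound 2 `Cc1cc(C(=O)O)ccc1CN1CCC[C@H](O[C@@H](CC(C)(C)O)c2cc(Cl)cc(Cl)c2)[C@@H]1c1ccccc1` with 8800 nM in this assay.

Compound 1 has the highest of the two numbers; compound 2 is its nearest neighbour, and the gap between the two lies beyond the scatter. Compound 3 `O=C(O)C12CC(CN3CCC[C@H](O[C@H](CO)c4cc(Cl)cc(Cl)c4)[C@@H]3c3ccccc3)(C1)C2` differs from compound 1 in one place: a group of 8 heavy atoms (6 carbon, 2 oxygen; 2 four-membered non-aromatic rings of carbon only) in place of a group of 12 heavy atoms (8 carbon, 2 nitrogen, 2 oxygen; one five-membered aromatic ring with 2 hetero atoms, one six-membered aromatic ring of carbon only), on a saturated chain carbon bound to an amine nitrogen in a ring. Within the data shown here, no step of this kind has been measured, so the size of the step from compound 1 to compound 3 is uncertain; a small rise in the number, near the edge of the scatter, is expected, giving a 1.6-fold higher number from compound 1 to compound 3 (0.21 log units; within the scatter). For compound 3 in this assay the estimate is 70000 nM, with a range from 15000 nM to 300000 nM.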

Compound 3, half-maximal effective concentration: > 200000 nM
Compound 3: a limit, no number; the forecaster's own chance of this, stated with the estimate: 30%; at least 2.8-fold (0.45 log units) between middle value and limit.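

In this assay compound 3 gives a limit, not a number: the limit of > 200000 nM in this assay, at which 1 of the 3 values shown sits.

On a saturated chain carbon bound to an amine nitrogen in a ring, putting the group with 2 four-membered non-aromatic rings of carbon only in place of the group with a five-membered and a six-membered aromatic ring gives an at least 4.6-fold higher number from compound 1 to compound 3 (0.66 log units; beyond the scatter). Among these compounds, this is the first reading of this place alone, and it shows that the number responds to the group held there; compound 1 and compound 2 differ in more than one place and offered no such reading.

From the compounds shown here alone, the true size of the step stays open, as does whether a pyridine ring or a piperidine ring carrying the carboxylic acid would keep the number near that of compound 1.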